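This account rests on a few compounds, and the source may have more. Where it says the series, first, only, none or still open, it means among the compounds named here.

- Compound 1 `Cc1ccc(/C=C(\C(=O)O)C(C)C)c2c1CC[C@H](C(C)(C)O)OC2=O`: > 100000 nM (a limit, not a number)
- Compound 2 `CC(=O)Oc1cc2c(CC[C@H](O)C(C)(C)O)c(C)ccc2cc1C(C)C`: 21700 nM
- Compound 3 `CC(=O)Oc1cc2c(CC[C@@H](O)C(C)(C)O)c(C)ccc2cc1C(C)C`: 41200 nM

These values come from a functional assay on HL-60 cells (Homo sapiens) for antiproliferative activity, read by CCK-8 assay, with a stated time of 72 h; a higher number here means a weaker inhibitor, a lower number a stronger inhibitor. Only compound 2 and compound 3 give numbers, and these two lie within the scatter of each other, so compound 3 stands level with compound 2. The step between them is a 1.9-fold higher number from compound 2 to compound 3 (0.28 log units; within the scatter). It reflects (the fact that compounds 2 and 3 differ only in the configuration as drawn), so it shows what a change of configuration on this chain does, and here that is nothing beyond the scatter.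

The next structure is compound 4 `CC(=O)Oc1cc2c(CC[C@H]3OC(C)(C)OC3(C)C)c(C)ccc2cc1C(C)C`, which has not yet been measured. The change leading to it is this: 2,2,5,5-tetramethyl-1,3-dioxolan-4-yl in place of 1,2-dihydroxy-2-methylpropyl on a saturated chain carbon, two bonds along the chain from an aromatic carbon. Going by the values given here, no measured step replaces the 1,2-dihydroxy-2-methylpropyl group, so the data give no direct size for this change. Among the compounds with values here, the expectation therefore starts from compound 3 at 41200 nM, and the small step of a 1.9-fold higher number from compound 2 to compound 3 (0.28 log units; within the scatter) offers the only guide along this chain. A modest move towards a lower number is expected, though with little confidence in its direction, and the estimated step is a 2.1-fold lower number from compound 3 to compound 4 (0.31 log units; beyond the scatter). For compound 4 the expected value is 20000 nM, with an estimated range from 5000 nM to 80000 nM.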

Compound 4, half-maximal inhibitory concentration: 17200 nM
Compound 4: middle estimate off by 1.2-fold (0.07 log units), on the high side, within the range that was stated.
By their numbers in this assay, from the lowest: compounds 4, 2 and 3 (each within the scatter of the next, the first and the last beyond it). At a limit, above all of these: compound 1.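

In this assay, going by these compounds alone, this is the first measured replacement of the 1,2-dihydroxy-2-methylpropyl group on this saturated chain carbon, and the outcome depends on the compound it is read from: a 2.4-fold lower number from compound 3 to compound 4 (0.38 log units; beyond the scatter), a modest step, whereas a 1.3-fold lower number from compound 2 to compound 4 (0.10 log units; within the scatter). The position therefore accepts the 2,2,5,5-tetramethyl-1,3-dioxolan-4-yl group, which is larger, carries a five-membered ring and has 0 hydrogen-bond donors against 2 in the group that leaves, and compound 4 stands level with compound 2 despite these differences. The compounds shown offer nothing that accounts for this result, so the step stands without a cause.

The compounds shown leave open whether the other configuration of the 2,2,5,5-tetramethyl-1,3-dioxolan-4-yl group would read the same, since compound 4 is the only compound here that carries this ring. They also leave open how a simple amine, a methyl ether or a longer alkyl chain would fare at this chain carbon, and so whether any group here can move the number far from the range that compounds 2, 3 and 4 occupy.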